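From Phenyl to Butyl on the Ring Nitrogen

This account rests on a few compounds, and the source may have more. Where it says the series, first, only, none or still open, it means among the compounds named here.

Compound 1 `CCn1nc(Cc2ccc(SC)cc2)c2ccccc2c1=O` and compound 2 `CSc1ccc(Cc2nn(-c3ccccc3)c(=O)c3ccccc23)cc1` share one core and differ only in the group on an aromatic nitrogen. In a functional assay on aorta with Alpha-1D adrenergic receptor (Rattus norvegicus) as the target (a lower number here means that less compound is needed, a higher number that more compound is needed for the effect), compound 1 gives > 100000 nM, which is a limit of the assay rather than a number. In this assay compound 2 likewise gives > 100000 nM, again a limit and not a number. The step that the two limits leave unreadable from compound 1 to compound 2 therefore has no readable size, and the limit of > 100000 nM in this assay, at which 2 of the 2 values shown sit, describes where both values stand. Compound 2 stands there too, with no number of its own.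

Compound 3 `CCCCn1nc(Cc2ccc(SC)cc2)c2ccccc2c1=O` is not yet measured. It changes compound 2 in one place: butyl in place of phenyl on an aromatic nitrogen. For the measured compounds named here, the only measured step, from compound 1 to compound 2, touches the same position but cannot be read. With both neighbours at the limit, no movement beyond the scatter can be foreseen in this assay, and another limit is the likelier outcome. Compound 3 is expected to give 150000 nM in this assay, within 50000 nM to 500000 nM. That estimate means an expected step that the limit leaves unreadable from compound 2 to compound 3, not beyond the scatter.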

Compound 3, half-maximal effective concentration: > 100000 nM
Compound 3: no number, only a limit; the forecaster's own chance of this, stated with the estimate: 85%; the middle value is on the limit's open side.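

Compound 3 gives > 100000 nM in this assay, which is a limit of the assay and not a number. No step among compound 1, compound 2 and compound 3 can be read, and one limit covers them all: the limit of > 100000 nM in this assay, at which 3 of the 3 values shown sit.

The compounds shown leave open whether ethyl, phenyl and butyl on the aromatic nitrogen differ at all in this assay.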